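The source may report more compounds than this note shows. Statements on the series, on what has been measured and on what is new or still open speak of the compounds shown alone.

Compound 1 `Cc1cc(C2=CC(=O)N3C[C@H](O[C@H](C)c4cc(C(F)(F)F)cc(C(F)(F)F)c4)[C@@H](c4ccc(F)cc4)C3C2)ccn1`: in an assay on CHO cells for displacement of a labelled ligand from Substance-P receptor (Homo sapiens), in the presence of a further agent that is not named here (a lower number here means a stronger inhibitor, a higher number a weaker inhibitor), compound 1 gives 34 nM
Compound 2 `C[C@@H](O[C@H]1CN2C(=O)C=C(c3ccc[n+]([O-])c3)CC2[C@@H]1c1ccc(F)cc1)c1cc(C(F)(F)F)cc(C(F)(F)F)c1`: in this assay compound 2 gives 2.3 nM

Among the compounds with values here, of the two compounds measured so far, compound 2 has the lower number, and its only neighbour is compound 1, which sits a 15-fold lower number from compound 1 to compound 2 (1.17 log units; beyond the scatter) away in the other direction. Compound 3 `C[C@@H](O[C@H]1CN2C(=O)C=C(c3cnn(C)c3)CC2[C@@H]1c1ccc(F)cc1)c1cc(C(F)(F)F)cc(C(F)(F)F)c1` has not yet been measured. It differs from compound 2 in one place: a group of 6 heavy atoms (4 carbon, 2 nitrogen; one five-membered aromatic ring with 2 hetero atoms) in place of a group of 7 heavy atoms (5 carbon, 1 nitrogen, 1 oxygen; one six-membered aromatic ring with 1 hetero atom), on a double-bonded ring carbon. Within the data shown here, the one measured step at this same position, a 15-fold lower number from compound 1 to compound 2 (1.17 log units; beyond the scatter), shows that the group on the double-bonded ring carbon can move the number by a large amount, but no step between the group that leaves and the 1-methyl-1H-pyrazol-4-yl group has been measured, so the direction of the change cannot be read from the data. As compound 2 holds the lowest number of the set, a return toward the number of compound 1 seems at least as likely as a further fall, and compound 3 is therefore expected to show a moderate rise, a 4.3-fold higher number from compound 2 to compound 3 (0.64 log units; beyond the scatter). The estimate for compound 3 in this assay is 10 nM, with a range from 2.5 nM to 40 nM.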

Compound 3, half-maximal inhibitory concentration: 5.4 nM
For compound 3 the middle estimate is 1.9-fold (0.27 log units) above the measured one; low and high end bracket the measured number.
By their numbers in this assay, from the lowest: compound 2; then compound 3; then compound 1.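

In this assay, the double-bonded ring carbon proves not to be limited to six-membered aromatic rings: the five-membered ring of the 1-methyl-1H-pyrazol-4-yl group gives a number still close to the low end of the set, with a 2.3-fold higher number from compound 2 to compound 3 (0.37 log units; beyond the scatter) and a 6.3-fold lower number from compound 1 to compound 3 (0.80 log units; beyond the scatter). Ring size alone therefore does not order these three compounds, since compound 3, with its five-membered ring, falls between two compounds that both carry six-membered rings, and the 2-methylpyridin-4-yl group of compound 1 is the one that stands apart from the other two. No measurement available here explains why these groups differ.

The compounds shown leave open whether this position would also accept a group with no aromatic ring, such as a morpholine or a carboxylic acid, and whether a longer chain in place of the methyl of the 1-methyl-1H-pyrazol-4-yl group would hold the number. Within the data shown here, they also leave open what the methyl of the 2-methylpyridin-4-yl group contributes on its own, as no pair here differs in that methyl alone.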